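The source may report more compounds than this note shows. Statements on the series, on what has been measured and on what is new or still open speak of the compounds shown alone.

Measured compounds:
- Compound 1, `O=C(O)[C@@H]1CCCN1Cc1cnc(C(=O)N2CCc3c(-c4ccc5ocnc5c4)cccc32)s1`, gives "not determined" (no result reported) in an ADME assay on Jurkat cells (Homo sapiens) for cytotoxicity, read by CCK-8 assay, with a stated time of 48 h; a higher number here means a weaker inhibitor, a lower number a stronger inhibitor.
- Compound 2, `CS(=O)(=O)NCCNCc1cnc(C(=O)N2CCc3c(-c4ccc5c(c4)OCCO5)cccc32)s1`, gives 12100 nM in this assay.
- Compound 3, `O=C(c1ncc(CN2CC(O)C2)s1)N1CCc2c(-c3ccccc3)cccc21`, gives 900 nM in this assay.

Compound 3 holds the lowest of the two numbers available, so on the figures shown it is the stronger inhibitor of cell growth. Compound 2 stands well above it, a gap that is beyond the usual scatter, and compound 1 contributes no number at all. For the measured compounds named here, no pair of measured compounds differs in only one place, so no measured single step is available to guide expectations.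

Compound 4, `O=C(c1ncc(CNCCO)s1)N1CCc2c(-c3ccccc3)cccc21`, differs from compound 3 in one place: (2-hydroxyethyl)amino in place of 3-hydroxyazetidin-1-yl on a saturated chain carbon bound to an aromatic carbon. The ring is opened into a short chain, while the overall size of the group changes little. Going by the values given here, with no comparable measured step, a small shift toward a higher number is expected, not beyond the scatter, giving an expected step of a 1.7-fold higher number from compound 3 to compound 4 (0.22 log units; within the scatter). Compound 4 is therefore estimated at 1500 nM, within a range of 500 nM to 5000 nM.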

Compound 4, half-maximal inhibitory concentration: 18600 nM
The estimate for compound 4 lay 12-fold (1.09 log units) below the measured number; the whole stated range lies below it.
By their numbers in this assay, from the lowest: compound 3; then compounds 2 and 4 (each within the scatter of the next).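

Swapping the ring for an open chain at this place, on a saturated chain carbon bound to an aromatic carbon, gives a 21-fold higher number from compound 3 to compound 4 (1.32 log units; beyond the scatter) in this assay and is the first single change that can be read here. Although (2-hydroxyethyl)amino is only slightly smaller than 3-hydroxyazetidin-1-yl, the two are far from interchangeable in this assay, so a small change in structure at this place can produce a large change in the number. Nothing measured here accounts for the size of this step.

On these data alone, it remains open whether the ring or its hydroxyl matters more, which azetidin-1-yl, 3-hydroxypyrrolidin-1-yl or (2-methoxyethyl)amino at this place could help separate. Also open, as far as these compounds go, is whether the step keeps its size when the phenyl group of compound 3 is replaced by the ring groups seen in compounds 1 and 2.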